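Methylating the Piperazine Nitrogen of Compound 2

The compounds below may be only part of what the source reports. "The series", "measured", "known", "first", "only" and "open" are said of these compounds alone.

Of the compounds shown here, three built on one shared core have been tested in a toxicity assay on L02 cells (Homo sapiens) for cytotoxicity, read by MTT assay, with a stated time of 72 h; a lower number here means a stronger inhibitor, a higher number a weaker inhibitor. Compound 1 `O=C1c2c[n+]([O-])c3ccccc3c2C(=O)c2c1c1ccccc1n2Cc1cn([C@H]2C[C@H](O)[C@@H](CO)O2)nn1` gives 280 nM. Within the data shown here, compound 3 `CC1(C)OC[C@@H](Cn2cc(Cn3c4c(c5ccccc53)C(=O)c3c[n+]([O-])c5ccccc5c3C4=O)nn2)O1` gives 2900 nM, and the single step between measured compounds, a 10-fold higher number from compound 1 to compound 3 (1.02 log units; beyond the scatter), shows how much a change at the aromatic nitrogen can move the number. Compound 2 `O=C1c2c[n+]([O-])c3ccccc3c2C(=O)c2c1c1ccccc1n2CCCCN1CCNCC1` gives 1380 nM, the second highest of the three numbers; it stands nearest to compound 3 and furthest from compound 1, both gaps beyond the scatter.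

Compound 4 `CN1CCN(CCCCn2c3c(c4ccccc42)C(=O)c2c[n+]([O-])c4ccccc4c2C3=O)CC1` differs from compound 2 in one place: methyl in place of hydrogen on an amine nitrogen in a ring. Among the measured compounds shown here, no measured step touches the amine nitrogen in the ring; the only measured step concerns a quite different group on the aromatic nitrogen, so it does not bear directly on this change. What enters is one carbon with no ring, no hydrogen-bond donor, no hydrogen-bond acceptor and no net charge, a small alteration, and the expectation for compound 4 in this assay is a step within the scatter, with no clear direction. Compound 4 is therefore estimated at 1400 nM, with a range from 500 nM to 4000 nM. The step so expected, a 1.0-fold higher number from compound 2 to compound 4 (0.01 log units; within the scatter), is small.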

Compound 4, half-maximal inhibitory concentration: 80 nM
Compound 4: the middle estimate sits 18-fold (1.24 log units) above what was measured; the measured number lies below the stated range.
By their numbers in this assay, from the lowest: compound 4; then compound 1; then compound 2; then compound 3.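

In this assay, the amine nitrogen in the six-membered ring proves to be a sensitive position: replacing piperazin-1-yl with 4-methylpiperazin-1-yl gives a 17-fold lower number from compound 2 to compound 4 (1.24 log units; beyond the scatter), a large step from the addition of one carbon with no ring and no net charge. Among these compounds, the earlier compounds could not show this, since their only measured step exchanged one whole group for another on the aromatic nitrogen, whereas here a single methyl in place of a hydrogen moves the number by a similar order of size. No measurement at hand explains why this methyl has so large an effect.

The compounds shown leave open whether the step belongs to methyl alone or would also appear with an ethyl or an acetyl group on the same ring nitrogen. They also leave open whether the same change would give a step of this size if the piperazine ring stood on a longer chain, or whether a morpholine ring in its place would fall closer to compound 2 or to compound 4.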